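This account rests on a few compounds, and the source may have more. Where it says the series, first, only, none or still open, it means among the compounds named here.

In a functional assay on A549 cells (Homo sapiens) for inhibition, read by MTT assay, with a stated time of 72 h (on this read-out lower numbers stand for stronger inhibition and higher numbers for weaker inhibition), compound 1 `Fc1ccc(-c2nnc(SCCCN3CCN(c4nc5ccccc5o4)CC3)o2)cc1` gives 75700 nM and compound 2 `COc1ccc(-c2nnc(SCCCN3CCN(c4nc5ccccc5s4)CC3)o2)cc1` gives 90300 nM while compound 3 `Fc1ccc(-c2nnc(SCCCN3CCN(c4nc5ccccc5s4)CC3)o2)cc1` gives 71700 nM and so stands within the scatter of both. Compound 4 `O=C(NCc1nnc(SCCCN2CCN(c3nc4ccccc4s3)CC2)o1)c1ccccc1` departs from compound 3 at one place, an aromatic carbon of the five-membered aromatic ring with 2 nitrogen and 1 oxygen, where benzamidomethyl comes in place of 4-fluorophenyl (benzamidomethyl in place of 4-fluorophenyl on an aromatic carbon). For the measured compounds named here, two measured steps bear on this only loosely. Fluoro in place of methoxy gave a 1.3-fold lower number from compound 2 to compound 3 (0.10 log units; within the scatter) and the change on the ring amine nitrogen gave a 1.1-fold lower number from compound 1 to compound 3 (0.02 log units; within the scatter) and neither leaves the scatter. Going by the values given here, no measured compound carries benzamidomethyl, so the data give no size for this change and no direction. In this assay no clear shift is therefore expected, though the uncertainty is wider than for the measured steps. The expected step is a 1.1-fold lower number from compound 3 to compound 4 (0.02 log units; within the scatter) as an estimate only. Compound 4 is expected at 68000 nM within an estimated range of 28000 nM to 150000 nM in this series.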

Compound 4, half-maximal inhibitory concentration: 88700 nM
Compound 4: middle estimate off by 1.3-fold (0.12 log units), on the low side; measured number inside the range.
By their numbers in this assay, from the lowest: compounds 3, 1, 4 and 2 (each within the scatter of the next).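

In this assay, benzamidomethyl in place of 4-fluorophenyl on the aromatic carbon of the five-membered ring gives a 1.2-fold higher number from compound 3 to compound 4 (0.09 log units; within the scatter), and benzamidomethyl in place of 4-methoxyphenyl at the same carbon gives a 1.0-fold lower number from compound 2 to compound 4 (0.01 log units; within the scatter), so both steps stay within the scatter. This position therefore accepts a group with more heavy atoms, an amide hydrogen-bond donor and an acceptor, and a carbon link to its benzene ring without a clear shift in the number, which the earlier changes of a ring substituent and of the group on the ring amine nitrogen could not show. No supporting measurement accounts for this result.

From the compounds shown here alone, it remains open whether an amine, a carboxylic acid or a small alkyl group on this carbon would move the number beyond the scatter. Going by these compounds, a longer chain in place of the methylene link of benzamidomethyl is equally open.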